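Biphenyl in place of styryl on the benzyl arm

The compounds below may be only part of what the source reports. "The series", "measured", "known", "first", "only" and "open" are said of these compounds alone.

Measured compounds:
compound 1 `COC(=O)/C=C/c1cccc(N(Cc2ccc(/C=C/c3c(Cl)cccc3Cl)cc2)C(=O)C(C)C)c1` – 195 nM
compound 2 `COC(=O)/C=C/c1cccc(N(Cc2ccc(/C=C/c3cccc(C(F)(F)F)c3)cc2)C(=O)C(C)C)c1` – 267 nM
compound 3 `COC(=O)/C=C/c1cccc(N(Cc2ccc(/C=C/c3cccc(C(F)(F)F)c3)cc2)C(=O)NC(C)C)c1` – 932 nM

In an assay on isolated protein with Bile acid receptor (Homo sapiens) as the target (a lower number here means that less compound is needed, a higher number that more compound is needed for the effect), compound 3 stands highest of the three numbers: compound 2 lies nearest, a 3.5-fold higher number from compound 2 to compound 3 (0.54 log units; beyond the scatter), and compound 1 furthest, with 195 nM, while compound 3 gives 932 nM. Compound 4 `COC(=O)/C=C/c1cccc(N(Cc2ccc(-c3cccc(OC)c3)cc2)C(=O)NC(C)C)c1` differs from compound 3 in one place: 3-methoxyphenyl in place of 2-(3-(trifluoromethyl)phenyl)ethenyl on an aromatic carbon. Within the data shown here, no measured step covers this change directly. Among the measured compounds shown here, the only step on this part of the molecule, a 1.4-fold higher number from compound 1 to compound 2 (0.14 log units; within the scatter), swapped one aryl group for another while keeping the ethenyl link, and its size was within the scatter. Compound 4 is therefore expected to give a number close to that of compound 3, with a 1.6-fold higher number from compound 3 to compound 4 (0.21 log units; within the scatter), and the estimate for compound 4 is 1500 nM, ranging from 400 nM to 6000 nM.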

Compound 4, half-maximal effective concentration: 1370 nM
Compound 4: the middle estimate sits 1.1-fold (0.04 log units) above what was measured, and the stated range covers the measured number.
By their numbers in this assay, from the lowest: compounds 1 and 2 (each within the scatter of the next); then compounds 3 and 4 (each within the scatter of the next).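

In this assay, with the isopropylamino carbonyl kept, the ethenyl link need not stay at this aromatic carbon, para to a large group: replacing 2-(3-(trifluoromethyl)phenyl)ethenyl with 3-methoxyphenyl gives a 1.5-fold higher number from compound 3 to compound 4 (0.17 log units; within the scatter). Because the link and the ring substituent change together, this single step cannot separate their contributions. No available evidence accounts for this result. The compounds shown leave open whether 3-methoxyphenyl gives a similar number with isopropyl on the carbonyl. They also leave open how an amine or a carboxylic acid on this aryl ring would read.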